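Swapping 1,2-dihydroxyethyl for oxiran-2-yl on compound 1

The compounds below may be only part of what the source reports. "The series", "measured", "known", "first", "only" and "open" are said of these compounds alone.

In a functional assay on Ramos cells (Homo sapiens) for antiproliferative activity (on this read-out higher numbers stand for weaker inhibition and lower numbers for stronger inhibition), compound 1 `Nc1ncnc2c1c(-c1ccc(Oc3ccccc3)cc1)cn2C[C@H]1CCCN1C[C@@H](O)CO` gives 13500 nM. Among the measured compounds shown here, this is the only number available, so it cannot yet be ranked against anything. For compound 2 `Nc1ncnc2c1c(-c1cnc3[nH]ccc3c1)cn2C[C@H]1CCCN1C[C@@H]1CO1` the record reads "not determined" (no result reported). Compound 3 `Nc1ncnc2c1c(-c1ccc(Oc3ccccc3)cc1)cn2C[C@H]1CCCN1C[C@@H]1CO1` has oxiran-2-yl in place of 1,2-dihydroxyethyl on a saturated chain carbon bound to an amine nitrogen in a ring. For the measured compounds named here, no measured pair shows this change, so any forecast in this assay is loose, but stronger inhibition is expected. The expected change is a 6.8-fold lower number from compound 1 to compound 3 (0.83 log units; beyond the scatter). Compound 3 is estimated at 2000 nM, with a range of 300 nM to 15000 nM.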

Compound 3, half-maximal inhibitory concentration: 8520 nM
Beside the measured number, compound 3's estimate is 4.3-fold (0.63 log units) below it, within the range that was stated.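

In this assay, putting oxiran-2-yl in place of 1,2-dihydroxyethyl gives a 1.6-fold lower number from compound 1 to compound 3 (0.20 log units; within the scatter), so the two compounds cannot be told apart on this read-out. At this place, on a saturated chain carbon bound to an amine nitrogen in a ring, a group with 2 hydrogen-bond donors and a three-membered ring with 0 donors read alike. Nothing available explains this result. From the compounds shown here alone, whether an amine, a carboxylic acid or a longer chain here would shift the number beyond the scatter stays open. So does whether this swap reads alike on another core.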